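This account rests on a few compounds, and the source may have more. Where it says the series, first, only, none or still open, it means among the compounds named here.

Measured compounds:
Compound 1 `Nc1ccccc1NC(=O)c1ccc(CSC(=S)N2CCN(c3ccccc3)CC2)cc1`: 87.4%
Compound 2 `Nc1ccccc1NC(=O)c1ccc(CSC(=S)N2CCCc3ccccc32)cc1`: 87.5%

Of the compounds shown here, two sharing a common core have been tested in a functional assay on MGC-803 cells (Homo sapiens) for antiproliferative activity, read by CCK-8 assay, with a stated time of 72 h, tested at 8 uM; on this read-out higher numbers stand for a stronger effect at the one concentration tested and lower numbers for a weaker effect. In this assay compound 1 gives 87.4%, and compound 2 gives 87.5%. Compound 1 stands as the lower of the two numbers, but its nearest neighbour, compound 2, lies within the scatter of it, so the two read-outs show no difference that can be trusted. Both sit at a high level of inhibition at the single concentration used.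

Compound 3 `N#Cc1ccc(N2CCN(C(=S)SCc3ccc(C(=O)Nc4ccccc4N)cc3)CC2)cc1` has not yet been measured. It differs from compound 1 in one place: cyano in place of hydrogen on an aromatic carbon. Going by the values given here, no pair of measured compounds separated by a single change is available, so the size of this step has to be judged from the two values alone, which both lie high and close together.

The step from compound 1 to compound 3 is expected to be small, a number 2.4 percentage points lower from compound 1 to compound 3 (within the scatter), and not beyond the scatter. Compound 3 is therefore estimated at 85%, with a range from 70% to 95%.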

Compound 3, a percentage reported as inhibition, at one concentration (the size of the read-out at that concentration, not a potency): 37.6%
For compound 3 the middle estimate is 47.4 percentage points above the measured one; measured number below the stated range.
By their numbers in this assay, from the lowest: compound 3; then compounds 1 and 2 (each within the scatter of the next).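

Putting cyano in place of hydrogen on an aromatic carbon, para to a large group, gives in this assay a number 49.8 percentage points lower from compound 1 to compound 3 (beyond the scatter). The earlier compounds shown here offered no single-change comparison, and this step shows that the position is not indifferent: the change from phenyl to 4-cyanophenyl, which adds only 2 heavy atoms and no ring, is enough to take the read-out well away from the high level of compound 1. Nothing available explains why this one substitution has so large an effect.

With a single substitution at a single position, the compounds shown leave open whether the loss is specific to cyano or would also follow from another group at the same carbon, such as a methoxy group, a chlorine atom or an amine. They also leave open whether cyano would have a comparable effect at another carbon of the same ring, or whether a similar substitution elsewhere on the core of compound 1 would change the read-out to a similar extent.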